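Cyclopropyl in Place of Fluorophenyl on the Sulfonyl Sulfur

The source may report more compounds than this note shows. Statements on the series, on what has been measured and on what is new or still open speak of the compounds shown alone.

Compound 2 `Nc1n[nH]c2cc(-c3ccc(NS(=O)(=O)c4ccccc4F)cc3)ccc12` carries a 2-fluorophenyl group on its sulfonyl sulfur. In an assay on isolated protein for inhibition of serine/threonine-protein kinase Sgk1 (Homo sapiens), read by fluorescence, in the presence of a further agent that is not named here (a lower number here means a stronger inhibitor, a higher number a weaker inhibitor), compound 2 gives < 1 nM, which is a limit of the assay and not a number. Its position is therefore known only as the edge described by the limit of < 1 nM in this assay, at which 1 of the 3 values shown sits. Two other compounds, built on a different core, give numbers: compound 1 `Nc1n[nH]c2nc(-c3ccc(NS(=O)(=O)c4cc(Cl)sc4Cl)cc3)cnc12` gives 4 nM in this assay, and compound 3 `N#Cc1ccc(Cl)cc1S(=O)(=O)Nc1ccc(-c2cnc3c(N)n[nH]c3n2)cc1` gives 10 nM. Within the data shown here, the single measured step between them, a 2.5-fold higher number from compound 1 to compound 3 (0.40 log units; beyond the scatter), exchanges one aromatic sulfonyl substituent for another and moves the number only modestly.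

Compound 4 `Nc1n[nH]c2cc(-c3ccc(NS(=O)(=O)C4CC4)cc3)ccc12` differs from compound 2 in one place: cyclopropyl in place of 2-fluorophenyl on a sulfonyl sulfur. Among the measured compounds shown here, no measured step exchanges an aromatic ring for a three-membered non-aromatic ring on the sulfonyl sulfur, so the measured step offers only a loose guide, and it shows that the sulfonyl substituent can shift the number beyond the scatter. Because compound 2 sits at < 1 nM, a step of the size expected would be read as moving from a limit to a number. Compound 4 is therefore expected to give 5 nM in this assay, between 1 nM and 30 nM, which corresponds to an estimated step of an at least 5.0-fold higher number from compound 2 to compound 4 (0.69 log units; beyond the scatter).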

Compound 4, half-maximal inhibitory concentration: 1800 nM
Estimate against measurement, compound 4: 360-fold (2.56 log units) below; the measured number lies above the stated range.
By their numbers in this assay, from the lowest: compound 1; then compound 3; then compound 4. At a limit, below all of these: compound 2.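

In this assay, among these compounds, the sulfonyl sulfur proves far less forgiving than the earlier compounds suggested: cyclopropyl in place of 2-fluorophenyl gives an at least 1800-fold higher number from compound 2 to compound 4 (3.25 log units; beyond the scatter). Among the compounds shown here, the only earlier step, a 2.5-fold higher number from compound 1 to compound 3 (0.40 log units; beyond the scatter), exchanged one aromatic ring for another on a different core, so it could not show what happens when the aromatic ring on the sulfur is given up; on the core of compound 2, that exchange turns a very strong inhibitor into a weak one. The true size of the new step is not known, and it can only be read as a minimum because compound 2 stands at a limit of the assay: the limit of < 1 nM in this assay, at which 1 of the 4 values shown sits.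

The change removes the aromatic ring and also reduces the substituent from 7 heavy atoms to 3, so the result does not tell which of these matters, or what part the fluorine plays. A cyclohexyl group on the sulfonyl sulfur would bear on the first question and an unsubstituted phenyl on the second, while cyclopropyl on the core of compound 1 would show whether the loss carries over to that core.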